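Carbamoylmethyl for benzyloxycarbonyl on a purine glycinamide

The source may report more compounds than this note shows. Statements on the series, on what has been measured and on what is new or still open speak of the compounds shown alone.

Measured compounds:
compound 1, `O=C(O)[C@@H]1CCCN1C(=O)CN(c1nc(Cl)nc2[nH]cnc12)C1CC1`, 34.9%
compound 2, `O=C(CN(c1nc(Cl)nc2[nH]cnc12)C1CC1)N[C@@H](CC(=O)OCc1ccccc1)C(=O)OCc1ccccc1`, 22.4%

Two compounds carry the shared core, each measured in a functional assay on the whole organism (Tail, strain ICR) with Mus musculus as the target, in the tail flick test, with a stated time of 60 min, at a dose of 25 umol/kg by the oral route; a higher number here means a stronger effect of the compound at the dose given, a lower number a weaker effect. Compound 1 gives 34.9%. Compound 2 gives 22.4%, which is the lower of the two numbers, standing below compound 1 by a gap beyond the scatter. Within the data shown here, no step between these two is computed, since they differ in more than one place, so their two values are all that can be read.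

Compound 3, `NC(=O)CC[C@H](NC(=O)CN(c1nc(Cl)nc2[nH]cnc12)C1CC1)C(=O)OCc1ccccc1`, has not yet been measured in this assay. It differs from compound 2 in a single place, (carbamoylmethyl in place of benzyloxycarbonyl on a saturated chain carbon, two bonds along the chain from an amide-type nitrogen and a carbonyl carbon).

Among the measured compounds shown here, with no measured step of this kind to lean on, the expectation rests on the range spanned by compound 1 and compound 2 alone. The step of a number 4.6 percentage points higher from compound 2 to compound 3 (within the scatter) is expected to be small, upward if anything, and possibly within the scatter. Compound 3 is therefore estimated to give 27%, with a range from 12% to 45%.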

Compound 3, a percentage reported as activity, at one dose (the size of the read-out at that dose, not a potency): 33.1%
The estimate for compound 3 lay 6.1 percentage points below the measured number; measured number inside the range.
By their numbers in this assay, from the lowest: compound 2; then compounds 3 and 1 (each within the scatter of the next).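

In this assay, among these compounds, the change of benzyloxycarbonyl to carbamoylmethyl on a saturated chain carbon, two bonds along the chain from an amide-type nitrogen and a carbonyl carbon, gives a number 10.7 percentage points higher from compound 2 to compound 3 (beyond the scatter) and so supplies the first readable step at this position. The benzyloxycarbonyl group, with its six-membered aromatic ring of carbon only, is thus not required here for the read-out at this dose, since its replacement by a group with no ring does not lower the number but modestly raises it. No measurement shown here explains this step.

On these data alone, one step at a single dose cannot separate the loss of the benzyloxycarbonyl group from the gain of the carbamoylmethyl group, so it remains open whether a carboxylic acid, an amine or a simple methyl group at this position would give a similar number. As far as these compounds go, it is also open whether a longer chain ending in the same primary amide would hold the gain, and whether the step would persist if the remaining benzyl ester of compound 3 gave way to a carboxylic acid.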